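Swapping chloro for methoxy on a weak compound

A few compounds are considered here, and "the series" means these few. Any claim that something is new, unique, unknown or untested is made for them only; others in the source may bear on it.

Measured so far in a functional assay on KYSE-450 cells (Homo sapiens) for inhibition, read by CCK-8 assay, with a stated time of 48 h; on this read-out higher numbers stand for weaker inhibition and lower numbers for stronger inhibition

Compound 1 `COc1ccc(CN(C(=O)CSC(=S)N2CCCC2)c2cc(OC)c(OC)c(OC)c2)cc1` gives 13800 nM
Compound 2 `COc1ccc(CN(C(=O)CN2CCN(C(C)=O)CC2)c2cc(OC)c(OC)c(OC)c2)cc1` gives 10800 nM
Compound 3 `COc1ccc(CN(C(=O)CSC(=S)N2CCN(C(=O)OC(C)(C)C)CC2)c2ccc(Cl)cc2)cc1` gives > 20000 nM as a limit, not a number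

Compound 3 stands at a limit of the assay and so has no exact value (the limit of > 20000 nM in this assay, at which 1 of the 3 values shown sits). Compound 4 `COc1ccc(CN(C(=O)CSC(=S)N2CCN(C(=O)OC(C)(C)C)CC2)c2ccc(OC)cc2)cc1` differs from compound 3 in one place (methoxy in place of chloro on an aromatic carbon): methoxy in place of chloro on an aromatic carbon, para to a large group, which turns 4-chlorophenyl into 4-methoxyphenyl.

For the measured compounds named here, no measured step touches that place. Going by the values given here, the only measured step (a 1.3-fold lower number from compound 1 to compound 2 (0.11 log units; within the scatter)) swaps a different group, so it gives no direct size for this change. The nearest guides are compound 1 at 13800 nM and compound 2 at 10800 nM, which show real numbers.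

A modest move toward stronger inhibition is expected (an at least 1.3-fold lower number from compound 3 to compound 4 (0.12 log units; that floor lies within the scatter)), though another limit is quite possible. The estimate for compound 4 is 15000 nM in this assay (expected range 6000 nM to 30000 nM).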

Compound 4, half-maximal inhibitory concentration: > 20000 nM
Compound 4: a limit, no number (the forecaster's own chance of this, stated with the estimate: 45%); middle value at least 1.3-fold (0.12 log units) from the limit.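

Compound 3 and compound 4 both give a limit rather than a number, so the step between them cannot be read: the limit of > 20000 nM in this assay, at which 2 of the 4 values shown sit.

The compounds shown leave open whether methoxy in place of chloro on this aromatic ring changes inhibition at all in this assay.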